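Pentyl for Tert-Butyl: Activity Expected to Return

The compounds below may be only part of what the source reports. "The series", "measured", "known", "first", "only" and "open" are said of these compounds alone.

compound 1 `CCCCCCCc1cccc(N2CCNCC2)n1`: 10 mg/kg
compound 2 `CC(C)(C)c1cccc(N2CCNCC2)n1`: > 300 mg/kg

In a functional assay on the whole organism with Mus musculus as the target, in the maximal electroshock model, with a stated time of 120 min (on this read-out higher numbers stand for an effect only at larger amounts of compound and lower numbers for an effect already at smaller amounts), compound 1 gives 10 mg/kg. For compound 2 this assay reports only a limit, > 300 mg/kg, not a number; compound 2 thus sits at the limit of > 300 mg/kg in this assay, at which 1 of the 2 values shown sits. Compound 3 `CCCCCc1cccc(N2CCNCC2)n1` differs from compound 2 by pentyl in place of tert-butyl on an aromatic carbon. Within the data shown here, no measured pair covers this change, so the size of the step is uncertain. The change is expected to bring a large lowering of the minimum effective dose, well beyond the scatter, estimated as an at least 10-fold lower number from compound 2 to compound 3 (1.00 log units; beyond the scatter). Compound 3 is therefore expected near 30 mg/kg, in a range from 10 mg/kg to 100 mg/kg.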

Compound 3, minimum effective dose: 10 mg/kg
Compound 3: the middle estimate sits 3.0-fold (0.48 log units) above what was measured; the range from low to high includes it.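

In this assay pentyl on this aromatic carbon brings an at least 30-fold lower number from compound 2 to compound 3 (1.47 log units; beyond the scatter), so the branched tert-butyl, not the presence of a chain, marks the inactive end of this small set. Shortening the straight chain of compound 1 to pentyl gives no change at the digits printed from compound 1 to compound 3 (within the scatter), showing that both straight chains tolerate this place equally. The first step has no upper bound, as compound 2 stands at a limit: the limit of > 300 mg/kg in this assay, at which 1 of the 3 values shown sits.

As far as these compounds go, whether a shorter straight chain such as propyl keeps this dose remains open. So does whether a less crowded branched chain such as isobutyl behaves like pentyl or like tert-butyl.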